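Cyano to thiazolyl swap on the aryl arm of compound 1

The source may report more compounds than this note shows. Statements on the series, on what has been measured and on what is new or still open speak of the compounds shown alone.

Measured so far in an assay on cells for binding affinity to Myc proto-oncogene protein (Homo sapiens); on this read-out lower numbers stand for stronger inhibition and higher numbers for weaker inhibition:
compound 1 `N#Cc1ccc(-c2cc(-c3ccc(C(N)=O)cc3)cc(-c3ccco3)n2)cc1`, 3000 nM
compound 2 `N#Cc1ccc(-c2cc(-c3ccc(C(N)=O)cc3)cc(-c3cncs3)n2)cc1`, 30000 nM
compound 3 `Cn1nncc1-c1cc(-c2ccc(C(N)=O)cc2)cc(-c2ccc(C#N)cc2)n1`, 40000 nM

Compound 1 gives the lowest number of the three. Compound 2 sits a 10-fold higher number from compound 1 to compound 2 (1.00 log units; beyond the scatter) away, compound 3 a 13-fold higher number from compound 1 to compound 3 (1.12 log units; beyond the scatter); between compound 2 and compound 3 the gap is a 1.3-fold higher number from compound 2 to compound 3 (0.12 log units; within the scatter).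

Compound 4 `NC(=O)c1ccc(-c2cc(-c3ccc(-c4nccs4)cc3)nc(-c3ccco3)c2)cc1` is not yet measured. It differs from compound 1 in one place: 1,3-thiazol-2-yl in place of cyano on an aromatic carbon. The measured steps all change the five-membered heteroaryl on the shared core and leave the cyano-bearing ring untouched, so none of them bears directly on this change. They only show that this assay responds strongly to changes in one arm of the core. For the present change the data offer no guide to direction, and the estimate is therefore centred near compound 1 with wide bounds.

Compound 4 is expected to give about 2500 nM in this assay, within 500 nM to 15000 nM, which would mean a step of a 1.2-fold lower number from compound 1 to compound 4 (0.08 log units; within the scatter).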

Compound 4, half-maximal inhibitory concentration: 5000 nM
Beside the measured number, compound 4's estimate is 2.0-fold (0.30 log units) below it, and the stated range covers the measured number.
By their numbers in this assay, from the lowest: compounds 1 and 4 (each within the scatter of the next); then compounds 2 and 3 (each within the scatter of the next).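

In this assay, putting 1,3-thiazol-2-yl in place of cyano on the aromatic carbon para to a large group gives a 1.7-fold higher number from compound 1 to compound 4 (0.22 log units; within the scatter), so this pair cannot be told apart despite the added five-membered aromatic ring. Among the compounds shown here, this is the first reading on the cyano-bearing ring, and in this pair the nitrile is not needed to hold the number, whereas replacing furan-2-yl on the other arm gave a 10-fold higher number from compound 1 to compound 2 (1.00 log units; beyond the scatter) and a 13-fold higher number from compound 1 to compound 3 (1.12 log units; beyond the scatter). Nothing measured here accounts for this tolerance.

Open, on these data alone, is whether a carboxylic acid or a primary amine on this carbon would read like cyano and 1,3-thiazol-2-yl. Also open, as far as these compounds go, is whether the same swap holds on compound 2, which carries 1,3-thiazol-5-yl in place of furan-2-yl.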